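Series notes: from ethyl to benzyl

The source may report more compounds than this note shows. Statements on the series, on what has been measured and on what is new or still open speak of the compounds shown alone.

In a functional assay on MDA-MB-231 cells (Homo sapiens) for antiproliferative activity, read by MTT assay, with a stated time of 24 h (on this read-out lower numbers stand for stronger inhibition and higher numbers for weaker inhibition), compound 1 `CCCCc1oc2ccccc2c1C(=O)c1cc(I)c(OCCCN2CCN(C)CC2)c(I)c1` gives 8760 nM and compound 2 `CCCCc1oc2ccccc2c1C(=O)c1cc(I)c(OCCCN2CCN(CC)CC2)c(I)c1` gives 18000 nM as the higher of the two numbers, which places compound 2 on the weaker side of this short series. The next member is compound 3 `CCCCc1oc2ccccc2c1C(=O)c1cc(I)c(OCCCN2CCN(Cc3ccccc3)CC2)c(I)c1`, still unmeasured. The change is phenyl in place of methyl on a saturated chain carbon bound to an amine nitrogen in a ring in the form of phenyl in place of methyl on a saturated chain carbon bound to an amine nitrogen in a ring, which also reads as ethyl to benzyl. Going by the values given here, only one measured step bears on it. That step is a 2.1-fold higher number from compound 1 to compound 2 (0.31 log units; beyond the scatter) and it is modest, made at the same place, with methyl in place of hydrogen. Among the compounds with values here, one step sets no trend, and the entering ring has no precedent among the measured compounds. A small further move toward a higher number is the leaning, with no clear step beyond the scatter expected. In this assay the expected change is a 1.2-fold higher number from compound 2 to compound 3 (0.09 log units; within the scatter) as a working figure. For compound 3 the estimated value is 22000 nM with an expected range from 8000 nM to 55000 nM for now.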

Compound 3, half-maximal inhibitory concentration: 15700 nM
Beside the measured number, compound 3's estimate is 1.4-fold (0.15 log units) above it, within the range that was stated.
By their numbers in this assay, from the lowest: compounds 1, 3 and 2 (each within the scatter of the next, the first and the last beyond it).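

Phenyl in place of methyl, with 6 heavy atoms entering where 1 leaves, gives a 1.1-fold lower number from compound 2 to compound 3 (0.06 log units; within the scatter) in this assay and so does not separate compound 2 from compound 3. The wider comparison, a 1.8-fold higher number from compound 1 to compound 3 (0.25 log units; within the scatter) and also within the scatter, shows that the place on a saturated chain carbon bound to an amine nitrogen in a ring can carry a six-membered aromatic ring without a step beyond the scatter from either earlier compound. The earlier step, a 2.1-fold higher number from compound 1 to compound 2 (0.31 log units; beyond the scatter) as the only one beyond the scatter, therefore does not extend into a steady rise with the size of the group, and compound 3 goes against any such reading; nothing available bears on why the numbers fall as they do.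

The compounds shown leave open whether a longer chain such as propyl or butyl at this place would stay within the same narrow band, or whether a change of another kind is needed to move the number clearly. From the compounds shown here alone, it also remains open whether a phenyl ring carrying a hydroxyl, a methoxy or a carboxylic acid, or a saturated ring such as cyclohexyl in its stead, would separate from compound 3.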